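Benzimidazolyl Swapped for Bromophenyl on the Sulfanyl Arm

This account rests on a few compounds, and the source may have more. Where it says the series, first, only, none or still open, it means among the compounds named here.

Three compounds sharing one core were tested in an ADME assay on GES1 cells (Homo sapiens) for inhibition, read by MTT assay, with a stated time of 72 h; a higher number here means a weaker inhibitor, a lower number a stronger inhibitor. Compound 1 `Cc1cc(Nc2cc(-c3ccccc3)[nH]n2)n2ncnc2n1` reports only a limit, > 50000 nM. Compound 2 `Cc1cc(Nc2cc(-c3ccccc3)[nH]n2)n2nc(SCc3cccc(Br)c3)nc2n1`, carrying a (3-bromobenzyl)sulfanyl group in place of a hydrogen, likewise reports only a limit, > 50000 nM. Going by the values given here, compound 3 `Cc1cc(Nc2cc(-c3ccccc3)[nH]n2)n2nc(SCc3nc4ccccc4[nH]3)nc2n1` is the single compound with a number, giving 27800 nM in this assay. Two of the three values shown are only a limit (the limit of > 50000 nM in this assay, at which 2 of the 3 values shown sit). The step of an at least 1.7-fold lower number from compound 1 to compound 3 (0.25 log units; that floor lies within the scatter) and the step of an at least 1.7-fold lower number from compound 2 to compound 3 (0.25 log units; that floor lies within the scatter) both rest on a floor that lies within the scatter, so compound 3 stands apart only faintly.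

Compound 4 `Cc1cc(Nc2cc(-c3ccccc3)[nH]n2)n2nc(SCc3ccccc3Br)nc2n1` differs from compound 3 in one place: 2-bromophenyl in place of 1H-benzimidazol-2-yl on a saturated chain carbon bound to a sulfur. This change runs opposite to the step of an at least 1.7-fold lower number from compound 2 to compound 3 (0.25 log units; that floor lies within the scatter), which put 1H-benzimidazol-2-yl in place of 3-bromophenyl. Compound 4 is therefore expected to give a higher number, probably back at the limit, an estimated step of a 1.8-fold higher number from compound 3 to compound 4 (0.25 log units; within the scatter). The estimate for compound 4 is 50000 nM, within 15000 nM to 120000 nM.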

Compound 4, half-maximal inhibitory concentration: 41100 nM
For compound 4 the middle estimate is 1.2-fold (0.09 log units) above the measured one, and the stated range covers the measured number.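

In this assay, putting the 2-bromophenyl group in place of the benzimidazolyl group gives a 1.5-fold higher number from compound 3 to compound 4 (0.17 log units; within the scatter), so the two compounds cannot be told apart, and a measured number on this arm does not depend on the benzimidazole. Exchanging 3-bromophenyl for 2-bromophenyl gives an at least 1.2-fold lower number from compound 2 to compound 4 (0.08 log units; that floor lies within the scatter), and adding the (2-bromobenzyl)sulfanyl group in place of hydrogen gives an at least 1.2-fold lower number from compound 1 to compound 4 (0.08 log units; that floor lies within the scatter), and neither floor shows a change beyond the scatter. These two steps remain floors because their starting compounds each report only a limit: the limit of > 50000 nM in this assay, at which 2 of the 4 values shown sit.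

Still open, going by these compounds, is whether any group on this arm can move the number clearly beyond the scatter. An amine or a carboxylic acid on the ring, or a longer chain in place of the benzyl group, lies outside what these compounds can tell.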